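One measured step and an untested group

The source may hold more compounds than are shown below. What is called first, only, known or untested is meant among the compounds shown, and "the series" means these compounds.

Measured so far:
compound 1 `CC(C)=CCC[C@]1(C)/C=C/[C@@H](OC(=O)C=C(C)C)[C@](C)(O)/C=C/C(=O)/C(CN(C(C)C)C(C)C)=C\C1`: 650 nM
compound 2 `CC(C)=CCC[C@]1(C)/C=C/[C@@H](OC(=O)C=C(C)C)[C@](C)(O)/C=C/C(=O)/C(C[Si](C)(C)C(C)(C)C)=C\C1`: 4200 nM

In a functional assay on A549 cells (Homo sapiens) for antiproliferative activity, read by MTT assay, with a stated time of 48 h (on this read-out lower numbers stand for stronger inhibition and higher numbers for weaker inhibition), compound 2 gives 4200 nM, the higher of the two numbers, and its nearest neighbour is compound 1 at 650 nM. Compound 3 `CC(C)=CCC[C@]1(C)/C=C/[C@@H](OC(=O)C=C(C)C)[C@](C)(O)/C=C/C(=O)/C(COC(=O)c2ccc([N+](=O)[O-])cc2)=C\C1` has not yet been measured. It keeps the shared core of compound 2 and differs by a group of 12 heavy atoms (7 carbon, 1 nitrogen, 4 oxygen; one six-membered aromatic ring of carbon only) in place of a group of 7 heavy atoms (6 carbon, 1 silicon; no ring), on a saturated chain carbon bound to a double-bonded ring carbon. The incoming ((4-nitrophenyl)carbonyl)oxy group sits on a saturated chain carbon bound to a double-bonded ring carbon.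

Going by the values given here, only one measured step bears on this change, and it falls at the same place: a 6.5-fold higher number from compound 1 to compound 2 (0.81 log units; beyond the scatter). That step is modest but beyond the scatter, so the number in this assay does move with the group held here. Among the compounds with values here, no measured compound carries the incoming group, so the direction is uncertain. Compound 2 holds the higher number, so a modest step towards a lower number is the more likely outcome. The expected change is a 2.3-fold lower number from compound 2 to compound 3 (0.37 log units; beyond the scatter). For compound 3 the estimated value is 1800 nM, within an expected range of 500 nM to 6500 nM.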

Compound 3, half-maximal inhibitory concentration: 1310 nM
Compound 3: middle estimate off by 1.4-fold (0.14 log units), on the high side; the measured number falls inside the stated range.
By their numbers in this assay, from the lowest: compounds 1 and 3 (each within the scatter of the next); then compound 2.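

The change from the silicon-bearing group to the ((4-nitrophenyl)carbonyl)oxy group gives a 3.2-fold lower number from compound 2 to compound 3 (0.51 log units; beyond the scatter) in this assay and shows that a second, very different group at this saturated chain carbon also gives a number clearly apart from that of compound 2. Set against the diisopropylamino group, the same ester gives a 2.0-fold higher number from compound 1 to compound 3 (0.30 log units; within the scatter) and so cannot be told apart from it on this read-out, which means that a nitrogen amine at this place is not required for a number in this range. Among the three compounds, compound 2 alone stands apart, yet nothing measured here accounts for why these groups fall where they do.

The three groups differ in their atoms, size and ring content all at once, so the compounds shown do not reveal which of these differences tracks with the number. A plain benzoate lacking the nitro group would test the part played by the nitro group, while a hydroxyl or an acetate ester at the same carbon would show how much of the aromatic ring is needed at all.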